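A few compounds are considered here, and "the series" means these few. Any claim that something is new, unique, unknown or untested is made for them only; others in the source may bear on it.

Series of lactam-linked aryl ethers and related compounds tested in a functional assay on MCF7 cells (Homo sapiens) for antiproliferative activity, read by MTT assay, with a stated time of 72 h; a higher number here means a weaker inhibitor, a lower number a stronger inhibitor. Going by the values given here, compound 1 `CC(C)(C)c1ccc(/C=C/C(=O)c2ccc(OCC(=O)N[C@H]3CCOC3=O)cc2)cc1` is the one member with a numerical result: in this assay compound 1 gives 16400 nM. Compound 2 `O=C1OCC[C@@H]1NC(=S)SCCOc1ccccc1` reaches only a limit, > 64000 nM in this assay. Compound 3 `O=C(CNc1ccc(Br)cc1)N[C@H]1CCOC1=O` likewise returns a limit of > 64000 nM in this assay. So compound 1 stands alone with a number, while the limit of > 64000 nM in this assay, at which 2 of the 3 values shown sit, describes the other two.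

Compound 4 `O=C(COc1ccc(C(=O)/C=C/c2cccc([N+](=O)[O-])c2)cc1)N[C@H]1CCOC1=O` differs from compound 1 in one place (3-nitrophenyl in place of 4-(tert-butyl)phenyl on a double-bonded chain carbon bound to a double-bonded chain carbon). Among the compounds with values here, no measured step between two compounds is available to calibrate this change, so in this assay no step beyond the usual scatter is expected from compound 1 to compound 4. Compound 4 is estimated at 15000 nM, with a range from 5000 nM to 50000 nM, an expected step of a 1.1-fold lower number from compound 1 to compound 4 (0.04 log units; within the scatter).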

Compound 4, half-maximal inhibitory concentration: > 64000 nM
Compound 4: only a limit was reported (the forecaster's own chance of this, stated with the estimate: 15%); at least 4.2-fold (0.63 log units) between middle value and limit.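

Going by these compounds alone, this is the first readable step at one position: on a double-bonded chain carbon bound to a double-bonded chain carbon, 3-nitrophenyl in place of 4-(tert-butyl)phenyl gives an at least 3.9-fold higher number from compound 1 to compound 4 (0.59 log units; beyond the scatter) in this assay. Going by these compounds, the value for compound 4 is a limit, > 64000 nM, so the full size of the step stays unknown. Compound 1 remains the only member with a number: the limit of > 64000 nM in this assay, at which 3 of the 4 values shown sit.

The compounds shown do not separate losing the tert-butyl group from gaining the nitro group. On these data alone, how a plain phenyl or an aminophenyl would read at this position remains open.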